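Amide substituent series: amine chain to carboxy-bearing chain

The source may report more compounds than this note shows. Statements on the series, on what has been measured and on what is new or still open speak of the compounds shown alone.

Compound 1 `CCn1c(C(=O)NCCCN(C)C)ccc1C(CC)(CC)c1ccc(OCCC(O)(CC)CC)c(C)c1` carries a 3-(dimethylamino)propyl on the amide-type nitrogen. In a functional assay on HepG2 cells (Homo sapiens) for antiproliferative activity, read by MTT assay, with a stated time of 48 h (a higher number here means a weaker inhibitor, a lower number a stronger inhibitor), compound 1 gives 110 nM, the lowest of the two numbers in hand. Compound 2 `CCn1c(C(=O)NCCN(C)C)ccc1C(CC)(CC)c1ccc(OCCC(O)(CC)CC)c(C)c1` shortens the chain; in this assay compound 2 gives 240 nM, and the step of a 2.2-fold higher number from compound 1 to compound 2 (0.34 log units; beyond the scatter). Compound 3 `CCOc1ccc(NC(=O)c2ccc(C(CC)(CC)c3ccc(OCCC(O)(CC)CC)c(C)c3)n2CC)cc1` puts a 4-ethoxyphenyl on the same nitrogen. For compound 3 this assay reports only a limit, > 50000 nM. The steps of an at least 450-fold higher number from compound 1 to compound 3 (2.65 log units; beyond the scatter) and an at least 200-fold higher number from compound 2 to compound 3 (2.31 log units; beyond the scatter) both run into (the limit of > 50000 nM in this assay, at which 1 of the 3 values shown sits).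

Compound 4 `CCC(C)C(NC(=O)c1ccc(C(CC)(CC)c2ccc(OCCC(O)(CC)CC)c(C)c2)n1CC)C(=O)O` is not yet measured. Relative to compound 1 the change is 1-carboxy-2-methylbutyl in place of 3-(dimethylamino)propyl on an amide-type nitrogen. As in compound 3, the dimethylamino-bearing chain is gone; the step to compound 3 is the closer guide, the step to compound 2 only shows that changing the chain length costs little. A large weakening is therefore expected, though a chain rather than a ring enters, so the expected step of a 140-fold higher number from compound 1 to compound 4 (2.13 log units; beyond the scatter) is set somewhat short of the step to compound 3. Compound 4 is estimated at 15000 nM, in the range 2500 nM to 60000 nM.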

Compound 4, half-maximal inhibitory concentration: 2620 nM
Compound 4: middle estimate off by 5.7-fold (0.76 log units), on the high side; the measured number falls inside the stated range.
By their numbers in this assay, from the lowest: compound 1; then compound 2; then compound 4. At a limit, above all of these: compound 3.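

Within the data shown here, on the amide-type nitrogen, 1-carboxy-2-methylbutyl is the first group without a dimethylamino end to give a readable number in this assay, with a 24-fold higher number from compound 1 to compound 4 (1.38 log units; beyond the scatter) and an 11-fold higher number from compound 2 to compound 4 (1.04 log units; beyond the scatter). Losing the dimethylamino-bearing chain therefore costs a large step here, but not always one that reaches the top of the assay's range. Compound 3 gives only a limit, so an at least 19-fold lower number from compound 3 to compound 4 (1.28 log units; beyond the scatter) reads as a bound, yet it still separates the chain from the 4-ethoxyphenyl: the limit of > 50000 nM in this assay, at which 1 of the 4 values shown sits.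

The compounds shown cannot separate the effect of the carboxylic acid from that of the branched chain carrying it, which a methyl ester or primary amide of that chain would address. Also open, going by these compounds, is whether a longer chain ending in dimethylamino, or one ending in a cyclic amine such as piperidine, extends the trend from compound 2 to compound 1.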